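This account rests on a few compounds, and the source may have more. Where it says the series, first, only, none or still open, it means among the compounds named here.

Measured in a functional assay on MDA-MB-468 cells (Homo sapiens) for cytotoxicity, read by sulforhodamine B assay, with a stated time of 48 h; a lower number here means a stronger inhibitor of growth, a higher number a weaker inhibitor of growth:
compound 1 `O=C1C(=O)N(CN2CCN(c3ccnc4cc(Cl)ccc34)CC2)c2cccc(Br)c21`: 15900 nM
compound 2 `O=C1C(=O)N(CN2CCN(c3ccnc4cc(Cl)ccc34)CC2)c2cc(Cl)ccc21`: 36600 nM
compound 3 `O=C1C(=O)N(CN2CCN(c3ccnc4cc(C(F)(F)F)ccc34)CC2)c2cccc(Br)c21`: 52200 nM

Compound 3 differs from compound 1 by one change, (trifluoromethyl in place of chloro on an aromatic carbon). That change carried a 3.3-fold higher number from compound 1 to compound 3 (0.52 log units; beyond the scatter). Compound 2 differs from compound 1 in its core; the difference between the two cores is not broken down here. Compound 4 `O=C1C(=O)N(CN2CCN(c3ccnc4cc(C(F)(F)F)ccc34)CC2)c2cc(Cl)ccc21` is not yet measured; it stands to compound 2 as compound 3 stands to compound 1, namely (trifluoromethyl in place of chloro on an aromatic carbon). The place is described in identical words in both pairs, so this is the same change, now made on the core of compound 2. Among the compounds with values here, only one earlier instance exists to rest on. A step of about the same size is expected in this assay for compound 4, a 3.1-fold higher number from compound 2 to compound 4 (0.50 log units; beyond the scatter), because the earlier instance gave a 3.3-fold higher number from compound 1 to compound 3 (0.52 log units; beyond the scatter). Compound 4 is accordingly estimated at 115000 nM, between 50000 nM and 260000 nM. A weak number of this size may also come back only as a limit.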

Compound 4, concentration for 50% growth inhibition: 26100 nM
Compound 4: the middle estimate sits 4.4-fold (0.64 log units) above what was measured; the measured number lies below the stated range.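

In this assay, trifluoromethyl in place of chloro on an aromatic carbon gives a 1.4-fold lower number from compound 2 to compound 4 (0.15 log units; within the scatter), so on the core of compound 2 the change has no readable effect. The two instances disagree, and the step seen on the core of compound 1 did not carry over to the core of compound 2: the same change on two cores in this assay, a 3.3-fold higher number (0.52 log units; beyond the scatter) from compound 1 to compound 3 and a 1.4-fold lower number (0.15 log units; within the scatter) from compound 2 to compound 4, 4.6-fold (0.66 log units) apart, beyond the scatter of two such steps. Within the data shown here, with only two pairs, this shows that the size of the step is not transferable between these two cores, but not which difference between the cores matters or what a further core would give.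

Open, on these data alone, is how an amine, a nitrile or a methoxy group would behave on the same aromatic carbon on either core. Also open, as far as these compounds go, is whether a longer chain in the linker would alter the picture.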